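Nitro for fluoro on the isatin-series core

A few compounds are considered here, and "the series" means these few. Any claim that something is new, unique, unknown or untested is made for them only; others in the source may bear on it.

Working notes on the series. For the measured compounds named here, in a functional assay on THP-1 cells (Homo sapiens) for inhibition, read by sulforhodamine B assay, with a stated time of 48 h, tested at 50 uM (a higher number here means more inhibition of growth at the concentration tested, a lower number less inhibition of growth), compound 1 `O=C1C(=O)N(CCCn2cc(COc3cc(=O)oc4ccccc34)nn2)c2ccc(F)cc21` gives 86%, the highest of the two numbers measured so far; compound 2 `O=C1C(=O)N(CCCCCn2cc(COc3cc(=O)oc4ccccc34)nn2)c2ccc(I)cc21` gives 45% in this assay, a number well beyond the scatter lower, though compound 2 differs from compound 1 in more than one place. Compound 3 `O=C1C(=O)N(CCCn2cc(COc3cc(=O)oc4ccccc34)nn2)c2ccc([N+](=O)[O-])cc21` is not yet measured. It differs from compound 1 by nitro in place of fluoro on an aromatic carbon. Going by the values given here, no single-change step has been measured, so the size of the step of a number 8 percentage points lower from compound 1 to compound 3 (within the scatter) is only an expectation, with a modest drop toward the lower side of compound 1 allowed for. Compound 3 is estimated at 78% in this assay, within 55% to 95%.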

Compound 3, percent growth inhibition at one concentration: 60%
Estimate against measurement, compound 3: 18 percentage points above, and the stated range covers the measured number.
By their numbers in this assay, from the lowest: compound 2; then compound 3; then compound 1.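

Nitro in place of fluoro on this aromatic carbon gives, in this assay, a number 26 percentage points lower from compound 1 to compound 3 (beyond the scatter). For the compounds shown here, with the rest of the structure unchanged, this is the first direct reading of this position: the group on this carbon alone moves growth inhibition beyond the scatter, and compound 3 remains well short of compound 1. Nothing measured here accounts for the drop.

On these data alone, an amine or a methoxy group on this carbon remains open. Also open, as far as these compounds go, are the separate contributions of the chain and the ring substituent, as compound 2 differs from compound 1 in more than one place.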